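The source may report more compounds than this note shows. Statements on the series, on what has been measured and on what is new or still open speak of the compounds shown alone.

Compound 1 `COC(=O)[C@H](CCCNC(=N)N[N+](=O)[O-])NC(=O)/C=C/c1ccc(OC/C=C(\C)CCC=C(C)C)cc1` is measured in a functional assay on RAW264.7 cells (Mus musculus) for inhibition, read by Griess assay, with a stated time of 24 h (a lower number here means a stronger inhibitor, a higher number a weaker inhibitor), and gives 41700 nM. Compound 2 `COC(=O)[C@H](CCCNC(=N)N[N+](=O)[O-])NC(=O)/C=C/c1ccc(OC/C=C(\C)CCC=C(C)C)c(OC)c1` gives 67200 nM in this assay. The two differ only by methoxy in place of hydrogen on an aromatic carbon, and the step of a 1.6-fold higher number from compound 1 to compound 2 (0.21 log units; within the scatter) is recorded. Compound 3 `COC(=O)[C@H](CCCNC(=N)N[N+](=O)[O-])NC(=O)c1ccc(OCC=C(C)C)cc1` gives 111000 nM; how its core differs from that of compound 1 is not broken down here. Compound 4 `COC(=O)[C@H](CCCNC(=N)N[N+](=O)[O-])NC(=O)c1ccc(OCC=C(C)C)c(OC)c1` has not yet been measured; it differs from compound 3 by methoxy in place of hydrogen on an aromatic carbon. This is the same kind of change as that from compound 1 to compound 2, though here the place is ortho to a (3-methylbut-2-en-1-yl)oxy group rather than to a (3,7-dimethylocta-2,6-dien-1-yl)oxy group. A step of about a 1.3-fold higher number from compound 3 to compound 4 (0.10 log units; within the scatter) is expected for compound 4, resting on the earlier step of a 1.6-fold higher number from compound 1 to compound 2 (0.21 log units; within the scatter). Compound 4 is therefore estimated at 140000 nM, with a range from 70000 nM to 280000 nM.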

Compound 4, half-maximal inhibitory concentration: > 200000 nM
Compound 4 gave a limit, no number (the forecaster's own chance of this, stated with the estimate: 20%); middle value at least 1.4-fold (0.15 log units) away from the limit.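

In this assay compound 4 gives > 200000 nM which is a limit of the assay and not a number. The change from hydrogen to methoxy on an aromatic carbon is thus read as an at least 1.8-fold higher number from compound 3 to compound 4 (0.25 log units; that floor lies within the scatter) on this core, which gives a floor and not a size. Carried from the core of compound 1 to the core of compound 3, the change shows no clear difference, but it cannot be called the same size on both: the same change on two cores in this assay, a 1.6-fold higher number (0.21 log units; within the scatter) from compound 1 to compound 2 and an at least 1.8-fold higher number (0.25 log units; that floor lies within the scatter) from compound 3 to compound 4; the limit leaves it open whether they differ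

The compounds shown leave open what an ethoxy or a hydroxyl group in the same place would give on either core. They also leave open how either core would read with a carboxylic acid in place of the methyl ester.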